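Trifluoromethyl for Nitro at the Assay Limit

The compounds below may be only part of what the source reports. "The series", "measured", "known", "first", "only" and "open" are said of these compounds alone.

In a functional assay on A549 cells (Homo sapiens) for inhibition, read by MTT assay, with a stated time of 72 h (a lower number here means a stronger inhibitor, a higher number a weaker inhibitor), compound 1 (`COc1ccc(/C=C/C(=O)c2c(O)cc(O)cc2OC)cc1`) gives > 50000 nM, which is a limit of the assay and not a number. Compound 2 (`COc1cc(O)cc(O)c1C(=O)/C=C/c1ccc([N+](=O)[O-])cc1`) gives > 50000 nM, which is likewise a limit. Compound 2 therefore stands with compound 1 at the limit of > 50000 nM in this assay, at which 2 of the 2 values shown sit.

The next structure, compound 3 (`COc1cc(O)cc(O)c1C(=O)/C=C/c1ccc(C(F)(F)F)cc1`), differs from compound 2 by trifluoromethyl in place of nitro on an aromatic carbon, para to a large group.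

Among the measured compounds shown here, only one measured step bears on this change: a step that the two limits leave unreadable from compound 1 to compound 2, with nitro in place of methoxy on an aromatic carbon. It involves the same ring position, but it provides no size to carry forward. The data therefore support no expected direction, and no shift beyond the scatter is predicted in this assay. The step expected is a number no higher from compound 2 to compound 3 (the limit leaves the size open). Compound 3 may well report only a limit again. For compound 3 the estimated value is 50000 nM, with an expected range from 20000 nM to 100000 nM.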

Compound 3, half-maximal inhibitory concentration: 15400 nM
Compound 3: middle estimate off by 3.2-fold (0.51 log units), on the high side; the whole stated range lies above it.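

Trifluoromethyl on this aromatic carbon, para to a large group, gives the first value in this assay that is a number and not a limit, and the change from nitro appears as an at least 3.2-fold lower number from compound 2 to compound 3 (0.51 log units; beyond the scatter). Measured against methoxy at the same place, the same group gives an at least 3.2-fold lower number from compound 1 to compound 3 (0.51 log units; beyond the scatter), so this position on the shared core can move the read-out, something the earlier pair could not show, as the step between those two compounds cannot be read. Both sizes remain open-ended, since the other two compounds give only a limit: the limit of > 50000 nM in this assay, at which 2 of the 3 values shown sit.

With a single compound reporting a number, the compounds shown leave open how far nitro and methoxy actually lie from trifluoromethyl, and whether anything particular to trifluoromethyl is at work. From the compounds shown here alone, whether a chlorine atom, a nitrile or an amine on the same aromatic carbon would also give a number, and how such a number would stand against that of compound 3, also remains open.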